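Restoring the N-Methyl Group on the Benzylic Amine

The source may report more compounds than this note shows. Statements on the series, on what has been measured and on what is new or still open speak of the compounds shown alone.

In an assay on CHO cells with 5-hydroxytryptamine receptor 1D (Homo sapiens) as the target (a higher number here means a weaker inhibitor, a lower number a stronger inhibitor), compound 1 `CN(CC1CC1)CC1(O)CCN(CCCc2c[nH]c3ccc(-n4cnnc4)cc23)CC1` gives 1.35 nM, while compound 2 `CC(=O)Nc1ccc(CNCC2(O)CCN(CCCc3c[nH]c4ccc(-n5cnnc5)cc34)CC2)cc1` gives 11 nM, the highest of the two numbers; the step of an 8.1-fold higher number from compound 1 to compound 2 (0.91 log units; beyond the scatter) places compound 2 well behind compound 1. Compound 3 `Cc1ccccc1CN(C)CC1(O)CCN(CCCc2c[nH]c3ccc(-n4cnnc4)cc23)CC1` differs from compound 2 by methyl(2-methylbenzyl)amino in place of (4-acetamidobenzyl)amino on a saturated chain carbon bound to a saturated ring carbon. Going by the values given here, this change brings back a tertiary amine as in compound 1, and the only step bearing on it, an 8.1-fold higher number from compound 1 to compound 2 (0.91 log units; beyond the scatter), suggests that the loss of the methyl on nitrogen cost potency. Compound 3 is therefore expected to show a lower number in this assay, a step of about a 3.7-fold lower number from compound 2 to compound 3 (0.56 log units; beyond the scatter), landing near 3 nM with a range of 1 nM to 10 nM.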

Compound 3, half-maximal inhibitory concentration: 1.3 nM
Beside the measured number, compound 3's estimate is 2.3-fold (0.36 log units) above it; measured number inside the range.
By their numbers in this assay, from the lowest: compounds 3 and 1 (each within the scatter of the next); then compound 2.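

In this assay, the step of an 8.5-fold lower number from compound 2 to compound 3 (0.93 log units; beyond the scatter) shows that the methyl(2-methylbenzyl)amino group is far better tolerated here than the (4-acetamidobenzyl)amino group, while the step of a 1.0-fold lower number from compound 1 to compound 3 (0.02 log units; within the scatter) shows that 2-methylphenyl and cyclopropyl on a saturated chain carbon bound to an amine nitrogen cannot be told apart. This position therefore accepts either ring on the tertiary amine. Nothing measured here explains this result. The change from compound 2 to compound 3 alters the methyl on nitrogen, the ring methyl and the acetamide together, so their separate shares remain unresolved. As far as these compounds go, whether an unsubstituted benzyl or a 2-chlorobenzyl group on this nitrogen would fit equally well also stays open.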